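Flipping One Ring Stereocentre on an Iminosugar

This account rests on a few compounds, and the source may have more. Where it says the series, first, only, none or still open, it means among the compounds named here.

Measured so far:
- compound 1, `CCC[C@@H]1NC[C@@H](O)[C@@H](O)[C@H](O)[C@H]1O`, 46%
- compound 2, `CC[C@H]1NC[C@@H](O)[C@@H](O)[C@H](O)[C@H]1O`, 1.2%

Both compounds were tested in an assay on isolated protein for inhibition of alpha-galactosidase (Coffea arabica), tested at 1000 uM; on this read-out higher numbers stand for more inhibition at the one concentration tested (going by the name of the read-out) and lower numbers for less inhibition. Compound 1 gives 46% in this assay, while compound 2 gives 1.2%. Compound 2 therefore stands at the bottom of the two numbers available, and its distance to compound 1 lies beyond the usual scatter of this assay, so compound 2 clearly shows the lower inhibition of the pair on this read-out.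

The next compound, compound 3, `CC[C@@H]1NC[C@@H](O)[C@@H](O)[C@H](O)[C@H]1O`, keeps every atom and bond of compound 2 and changes only one thing: the two compounds have the same atoms and bonds and differ only in configuration as drawn: 1 of 5 stereo elements differ; a stereocentre at a saturated ring carbon is drawn R in compound 2 and S in compound 3. Going by the values given here, no step between two measured compounds of this kind is available, so the size of the effect of such a flip cannot be read from the measured pairs. Because the starting point of compound 2 is 1.2%, there is little room for the number to fall; the open question is whether it rises.

Compound 3 is expected to show a step of a number 28.8 percentage points higher from compound 2 to compound 3 (beyond the scatter) in this assay. The estimate for compound 3 is 30%, with a range from 5% to 60%.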

Compound 3, a percentage reported as inhibition, at one concentration (the size of the read-out at that concentration, not a potency): 7.5%
Estimate against measurement, compound 3: 22.5 percentage points above, within the range that was stated.
By their numbers in this assay, from the lowest: compounds 2 and 3 (each within the scatter of the next); then compound 1.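

In this assay, going by these compounds alone, flipping the ring stereocentre amounts to a number 6.3 percentage points higher from compound 2 to compound 3 (within the scatter), so at this position the change in configuration alone gives no step that can be told apart from the ordinary spread of repeated measurements, and this pair isolates that single change: the fact that compounds 2 and 3 differ only in the configuration as drawn. The chain is a different matter: with the drawn ring configuration kept, hydrogen in place of methyl on a saturated chain carbon, two bonds along the chain from a saturated ring carbon, gives a number 38.5 percentage points lower from compound 1 to compound 3 (beyond the scatter). Among these three compounds, then, the large step comes with the chain change, while the stereocentre flip stays within the scatter.

Within the data shown here, the flip is seen only on the chain shared by compound 2 and compound 3, with both numbers near the bottom of the scale, so whether it would matter on the chain of compound 1 stays open. Also open, as far as these compounds go, is how a longer chain, or an amine or a carboxylic acid on the chain, would read in this assay.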